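Benzofuran 5-lipoxygenase series: tert-butyl to carboxyethyl swap

The compounds below may be only part of what the source reports. "The series", "measured", "known", "first", "only" and "open" are said of these compounds alone.

Measured so far:
compound 1 `COc1ccc(Cc2oc3c(Cl)cc(C(C)(C)C)c(O)c3c2C)cc1`: 99 nM
compound 2 `CCCc1cc(F)c2oc(Cc3ccc(OC)cc3)c(C)c2c1O`: 7 nM
compound 3 `CCCc1cc(Cl)c2oc(Cc3ccc(OC)cc3OC)c(C)c2c1O`: 13 nM

In a functional assay for inhibition of Polyunsaturated fatty acid 5-lipoxygenase (Homo sapiens), in the absence of a further agent (a lower number here means a stronger inhibitor, a higher number a weaker inhibitor), compound 1 gives the highest of the three numbers recorded. The nearest of the other two is compound 3, whose value is lower by a margin beyond the scatter; the furthest is compound 2, also lower by a margin beyond the scatter. None of these three pairs differs in a single place, so no clean step can be read from the measured set.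

Compound 4 `COc1ccc(Cc2oc3c(Cl)cc(CCC(=O)O)c(O)c3c2C)cc1` is the next entry and has not yet been measured in this assay. Relative to compound 1 it carries 2-carboxyethyl in place of tert-butyl on an aromatic carbon. For the measured compounds named here, nothing among the measured compounds isolates a change of this kind, so there is no precedent for the size or direction of the resulting step. As far as these compounds go, both the carboxy-bearing chain and the loss of the branched substituent are untested here.

Without a comparable step, the working expectation is that the value of compound 4 does not move beyond the scatter from compound 1, and the estimate is 150 nM with a range from 40 nM to 600 nM. That estimate corresponds to an expected step of a 1.5-fold higher number from compound 1 to compound 4 (0.18 log units; within the scatter).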

Compound 4, half-maximal inhibitory concentration: 2130 nM
The estimate for compound 4 lay 14-fold (1.15 log units) below the measured number; measured number outside the range, above it.
By their numbers in this assay, from the lowest: compounds 2 and 3 (each within the scatter of the next); then compound 1; then compound 4.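

In this assay, for the compounds shown here, the position ortho to the hydroxy group and meta to the chloro group is sensitive to its substituent: replacing tert-butyl with 2-carboxyethyl gives a 22-fold higher number from compound 1 to compound 4 (1.33 log units; beyond the scatter) as the first single-place step, and it lies beyond the scatter. With the rest of the core of compound 1 held fixed, tert-butyl is clearly preferred here over this chain, which brings one hydrogen-bond donor and one hydrogen-bond acceptor absent from tert-butyl. No measurement of any property of these compounds bears on this step, and its origin remains unassigned.

The compounds shown do not separate the loss of tert-butyl from the entry of the carboxylic acid, and a methyl ester or primary amide on the same chain, or a propyl group on the core of compound 1, would help to tell these apart. Going by these compounds alone, compounds 2 and 3 differ from compound 1 and compound 4 in more than one place, so no steps to them can be read, and the effect of chain length at this position remains open.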